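Compound 4 from compound 1: para bromo for para methoxy

This account rests on a few compounds, and the source may have more. Where it says the series, first, only, none or still open, it means among the compounds named here.

Among the compounds with values here, in a functional assay on A549 cells (Homo sapiens) for inhibition, read by MTT assay, with a stated time of 24 h (a higher number here means a weaker inhibitor, a lower number a stronger inhibitor), compound 1 `COc1ccc(-n2cc(CN3C(=O)C[C@@H]4CC[C@@]3(C)C4(C)C)nn2)cc1` gives 50 nM, the lowest of the three numbers so far. Compound 2 `CC1(C)[C@H]2CC[C@]1(C)N(Cc1cn(-c3ccccc3Br)nn1)C(=O)C2` gives 130 nM and compound 3 `COc1cccc(-n2cc(CN3C(=O)C[C@@H]4CC[C@@]3(C)C4(C)C)nn2)c1` gives 240 nM. From the compounds shown here alone, compound 4 `CC1(C)[C@H]2CC[C@]1(C)N(Cc1cn(-c3ccc(Br)cc3)nn1)C(=O)C2` is untested; it differs from compound 1 by bromo in place of methoxy on an aromatic carbon. Within the data shown here, no measured step replaces methoxy with bromo on the same aromatic carbon; the nearest bearings are a 2.6-fold higher number from compound 1 to compound 2 (0.41 log units; beyond the scatter), where bromo appears on a different carbon of the ring as the methoxy leaves, and a 4.8-fold higher number from compound 1 to compound 3 (0.68 log units; beyond the scatter). Both departures from compound 1 raise the number modestly, so a modest rise beyond the scatter is expected here too, a 2.2-fold higher number from compound 1 to compound 4 (0.34 log units; beyond the scatter). Compound 4 is therefore estimated at 110 nM, within 40 nM to 300 nM.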

Compound 4, half-maximal inhibitory concentration: 80 nM
Beside the measured number, compound 4's estimate is 1.4-fold (0.14 log units) above it; the range from low to high includes it.
By their numbers in this assay, from the lowest: compounds 1, 4, 2 and 3 (each within the scatter of the next, the first and the last beyond it).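

The step of a 1.6-fold higher number from compound 1 to compound 4 (0.20 log units; within the scatter) does not separate bromo from methoxy on this aromatic carbon, so the two groups cannot be told apart here. Within the data shown here, the step of a 1.6-fold lower number from compound 2 to compound 4 (0.21 log units; within the scatter) likewise does not separate compound 2 from compound 4, whereas a 3.0-fold lower number from compound 3 to compound 4 (0.48 log units; beyond the scatter) is the only new step that clears the scatter. No measurement shown explains these numbers. Still open, from the compounds shown here alone, is whether an amine, a carboxylic acid or a longer chain in place of bromo on this aromatic carbon would keep the number in the same range.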